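A few compounds are considered here, and "the series" means these few. Any claim that something is new, unique, unknown or untested is made for them only; others in the source may bear on it.

In a functional assay on A549 cells (Homo sapiens) for cytotoxicity, read by MTT assay, with a stated time of 72 h (on this read-out lower numbers stand for stronger inhibition and higher numbers for weaker inhibition), compound 2 `COc1cc(/C=C/C(=O)Nc2cc3c(Nc4ccc(F)c(Cl)c4)ncnc3cc2OC)cc(OC)c1` is reported as "not active" (no number reported), so it stands without a number. Compound 1 `COc1ccc(/C=C/C(=O)Nc2cc3c(Nc4ccc(F)c(Cl)c4)ncnc3cc2O[C@H]2CCOC2)c(OC)c1OC` gives 70 nM and also carries oxolan-3-yl on an oxygen on an aromatic ring, but it differs from compound 2 in more than one place. Compound 3 is `COc1cc(/C=C/C(=O)Nc2cc3c(Nc4ccc(F)c(Cl)c4)ncnc3cc2O[C@H]2CCOC2)cc(OC)c1`. The change under study is oxolan-3-yl in place of methyl on an oxygen on an aromatic ring. Among the compounds with values here, no measured step isolates this change, so a large step toward stronger inhibition in this assay is expected only loosely, resting on compound 1 at 70 nM. The estimated value for compound 3 is 300 nM, with an expected range of 50 nM to 3000 nM.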

Compound 3, half-maximal inhibitory concentration: 10800 nM
The estimate for compound 3 lay 36-fold (1.56 log units) below the measured number, outside the stated range (above it).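

In this assay compound 3 gives 10800 nM, while compound 2, with methyl in place of oxolan-3-yl on the oxygen, has no number, so this change has no readable size. With oxolan-3-yl held fixed, the aryl group weighs heavily: 3,5-dimethoxyphenyl in place of 2,3,4-trimethoxyphenyl is a 150-fold higher number from compound 1 to compound 3 (2.19 log units; beyond the scatter). Nothing shown here explains either result. Still open, from the compounds shown here alone, is whether 2,3,4-trimethoxyphenyl keeps its advantage with methyl on that oxygen, and how a longer chain ending in an amine would read there.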